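Sulfonyl for amide on the ring nitrogen of compound 1

A few compounds are considered here, and "the series" means these few. Any claim that something is new, unique, unknown or untested is made for them only; others in the source may bear on it.

Compound 1 `COc1ccc(-c2cn3cc(C4=CCN(C(=O)c5ccccc5C(F)(F)F)CC4)ccc3n2)cc1OC` carries a (2-(trifluoromethyl)phenyl)carbonyl group on an amine nitrogen in a ring of its shared core. Among the measured compounds shown here, in an ADME assay on HEK293 cells (Homo sapiens) for cytotoxicity, read by MTT assay, with a stated time of 48 h (a lower number here means a stronger inhibitor, a higher number a weaker inhibitor), compound 1 gives 82900 nM, the highest of the two numbers measured so far. For the measured compounds named here, its only neighbour is compound 2 `COc1ccc(-c2cn3cc(C4=CCN(C(=O)C(C)(C)C)CC4)ccc3n2)cc1OC`, which has tert-butyl in place of 2-(trifluoromethyl)phenyl on the carbonyl carbon; in this assay compound 2 gives 66600 nM, and the step of a 1.2-fold lower number from compound 1 to compound 2 (0.10 log units; within the scatter) lies within the scatter.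

Compound 3 `COc1ccc(-c2cn3cc(C4=CCN(S(=O)(=O)c5ccccc5)CC4)ccc3n2)cc1OC` is not yet measured. It differs from compound 1 as follows: phenylsulfonyl in place of (2-(trifluoromethyl)phenyl)carbonyl on an amine nitrogen in a ring.

Going by the values given here, the one measured step, from compound 1 to compound 2, exchanges the group on the carbonyl carbon and moves the number by a 1.2-fold lower number from compound 1 to compound 2 (0.10 log units; within the scatter), which is within the scatter; no measured step exchanges the carbonyl itself for a sulfonyl. Among the compounds with values here, with only that step to rest on, no change beyond the scatter is expected from compound 1 to compound 3, the expected step being a 1.1-fold lower number from compound 1 to compound 3 (0.04 log units; within the scatter). Compound 3 is therefore estimated at 75000 nM in this assay, with a range from 35000 nM to 160000 nM.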

Compound 3, half-maximal inhibitory concentration: 65600 nM
Compound 3: middle estimate off by 1.1-fold (0.06 log units), on the high side; the measured number falls inside the stated range.
By their numbers in this assay, from the lowest: compounds 3, 2 and 1 (each within the scatter of the next).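

In this assay the change from a carbonyl to a sulfonyl on the amine nitrogen in a ring is now read directly, and it stays within the scatter against both amides (a 1.3-fold lower number from compound 1 to compound 3 (0.10 log units; within the scatter); a 1.0-fold lower number from compound 2 to compound 3 (0.01 log units; within the scatter)). The earlier step varied only the group on the carbonyl carbon, whereas these two steps replace the carbonyl as well, so this position has now taken an aryl amide, an alkyl amide and an aryl sulfonyl without any step beyond the scatter among compounds 1, 2 and 3. The step from compound 1 also removes the trifluoromethyl group, so it does not isolate the sulfonyl, and no evidence here bears on why the numbers stay so close.

Still open, going by these compounds, is whether an amine or a carboxylic acid on the phenyl ring of the phenylsulfonyl group, or a longer chain in place of that ring, would give a step beyond the scatter. The shared core is the same in compounds 1, 2 and 3, so these steps say nothing about changes elsewhere in the molecule, and they describe only this assay rather than any other read-out.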